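The source may report more compounds than this note shows. Statements on the series, on what has been measured and on what is new or still open speak of the compounds shown alone.

Measured compounds:
- compound 1 `COC(=O)c1cccn1-c1ccc(Nc2ncc(Cl)c(Nc3ccccc3NS(C)(=O)=O)n2)c(OC)c1`: in a functional assay on KARPAS-299 cells (Homo sapiens) for antiproliferative activity, read by MTT assay, with a stated time of 4 h (on this read-out lower numbers stand for stronger inhibition and higher numbers for weaker inhibition), compound 1 gives 790 nM
- compound 2 `COc1cc(-n2cccc2C(=O)NCCO)ccc1Nc1ncc(Cl)c(Nc2ccccc2NS(C)(=O)=O)n1`: in this assay compound 2 gives 45 nM

Going by the values given here, compound 2 holds the lowest number of the two measured; its only neighbour is compound 1, and the step of an 18-fold lower number from compound 1 to compound 2 (1.24 log units; beyond the scatter) lies beyond the scatter. Compound 3 `CCN(CC)C(=O)c1cccn1-c1ccc(Nc2ncc(Cl)c(Nc3ccccc3NS(C)(=O)=O)n2)c(OC)c1` differs from compound 2 by diethylamino in place of (2-hydroxyethyl)amino on a carbonyl carbon. Among the compounds with values here, the one measured step that bears on this carbonyl position is an 18-fold lower number from compound 1 to compound 2 (1.24 log units; beyond the scatter), where the (2-hydroxyethyl)amino group entered in place of methoxy. Within the data shown here, compound 3 removes that group again, though for diethylamino rather than methoxy, so no measured pair covers the change exactly. Because an 18-fold lower number from compound 1 to compound 2 (1.24 log units; beyond the scatter) was large, a move back toward the number of compound 1 is expected, with a rise in this assay for compound 3 of roughly a 4.4-fold higher number from compound 2 to compound 3 (0.65 log units; beyond the scatter). The estimate for compound 3 in this assay is 200 nM, within 60 nM to 700 nM.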

Compound 3, half-maximal inhibitory concentration: 105 nM
The estimate for compound 3 lay 1.9-fold (0.28 log units) above the measured number; the range from low to high includes it.
By their numbers in this assay, from the lowest: compound 2; then compound 3; then compound 1.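

In this assay the gain at this carbonyl carbon does not depend on the (2-hydroxyethyl)amino group alone: diethylamino in place of methoxy gives a 7.5-fold lower number from compound 1 to compound 3 (0.88 log units; beyond the scatter) on its own, so an amide without the hydroxyl keeps much of the improvement over the ester. The choice of amide group still matters, with a 2.3-fold higher number from compound 2 to compound 3 (0.37 log units; beyond the scatter) for the exchange of (2-hydroxyethyl)amino for diethylamino. No supporting data on hand account for either step.

Compounds 2 and 3 differ both in the hydroxyl and in the second ethyl group on nitrogen, so the two contributions stay unseparated; ethylamino or bis(2-hydroxyethyl)amino at this carbon would bear on that. Going by these compounds, how a longer chain such as (3-hydroxypropyl)amino, a cyclic amine such as morpholine, or the free carboxylic acid would compare also remains open.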